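A few compounds are considered here, and "the series" means these few. Any claim that something is new, unique, unknown or untested is made for them only; others in the source may bear on it.

Compound 1, `CC(C)(C)OC(=O)N(Cc1ccco1)C(=O)c1ccc(CN2C(=O)c3ccccc3C2=O)cc1`, gives in an ADME assay on RAW264.7 cells (Mus musculus) for cytotoxicity, read by WST assay (on this read-out lower numbers stand for higher toxicity in this test and higher numbers for lower toxicity in this test), a value that is a limit of the assay: > 100000 nM.
Compound 2, `O=C(NCc1ccco1)c1ccc(CN2C(=O)c3ccccc3C2=O)cc1`, gives in this assay a value that is a limit of the assay: > 100000 nM.
Compound 3, `CC(C)(C)OC(=O)N(Cc1ccco1)C(=O)c1ccc(Cn2sc3ccccc3c2=O)cc1`, gives in this assay a value that is a limit of the assay: > 100000 nM.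

The change from compound 1 to compound 2 is hydrogen in place of tert-butoxycarbonyl on an amide-type nitrogen, and it made a step that the two limits leave unreadable from compound 1 to compound 2. The two cores differ by a group of 10 heavy atoms (7 carbon, 1 nitrogen, 1 oxygen, 1 sulfur; one five-membered aromatic ring with 2 hetero atoms, one six-membered aromatic ring of carbon only) in place of a group of 11 heavy atoms (8 carbon, 1 nitrogen, 2 oxygen; one five-membered non-aromatic ring with 1 hetero atom, one six-membered aromatic ring of carbon only), on a saturated chain carbon bound to an aromatic carbon, which made a step that the two limits leave unreadable from compound 1 to compound 3. Compound 4, `O=C(NCc1ccco1)c1ccc(Cn2sc3ccccc3c2=O)cc1`, has not yet been measured in this assay. It differs from compound 3 by hydrogen in place of tert-butoxycarbonyl on an amide-type nitrogen, the same change as that from compound 1 to compound 2, at a place described in the same words. The step expected from compound 3 to compound 4 is a number no higher from compound 3 to compound 4 (the limit leaves the size open), set beside a step that the two limits leave unreadable from compound 1 to compound 2; this rests on (the limit of > 100000 nM in this assay, at which 3 of the 3 values shown sit), so no sign of a measurable step is available. For compound 4 the estimated value in this assay is 100000 nM, expected to fall between 40000 nM and 300000 nM, most likely reported again as a limit.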

Compound 4, concentration lethal to 50% of the cells: > 100000 nM
Compound 4 gave a limit, no number; the forecaster's own chance of this, stated with the estimate: 85%; the middle value sits exactly at the limit.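

Compound 3 and compound 4 both sit at a limit in this assay, so the step between them, hydrogen in place of tert-butoxycarbonyl on an amide-type nitrogen, cannot be read. The compounds shown leave open whether either change in structure shifts the cytotoxicity at all, as no actual number is available: the limit of > 100000 nM in this assay, at which 4 of the 4 values shown sit.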